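Notes on the step from compound 2 to compound 3

A few compounds are considered here, and "the series" means these few. Any claim that something is new, unique, unknown or untested is made for them only; others in the source may bear on it.

- compound 1 `O=C1C(Nc2ccc(Br)cc2)=CC(=O)c2c1nc1n2[C@H]2OC[C@@H](O)[C@H]2OC1` gives 1980 nM
- compound 2 `Cc1ccc(NC2=CC(=O)c3c(nc4n3[C@H]3OC[C@@H](O)[C@H]3OC4)C2=O)cc1C` gives 4090 nM

In a functional assay on ECa-109 cells for inhibition, with ECa-109 cell line (Homo sapiens) as the target, read by sulforhodamine B assay (a lower number here means a stronger inhibitor, a higher number a weaker inhibitor), compound 2 holds the higher of the two numbers, at 4090 nM. The next compound is compound 3 `O=C1C(N2CCCC2)=CC(=O)c2c1nc1n2[C@H]2OC[C@@H](O)[C@H]2OC1`, with this change: pyrrolidin-1-yl in place of (3,4-dimethylphenyl)amino on a double-bonded ring carbon; pyrrolidin-1-yl stands in place of (3,4-dimethylphenyl)amino on a double-bonded ring carbon. Within the data shown here, the only measured step, a 2.1-fold higher number from compound 1 to compound 2 (0.32 log units; beyond the scatter), is modest and swaps one phenyl group for another on the amine nitrogen, so it offers only loose guidance here. Among the measured compounds shown here, no measured compound carries pyrrolidin-1-yl, so a modest rise with uncertain direction is expected. The estimated step is a 1.5-fold higher number from compound 2 to compound 3 (0.17 log units; within the scatter). Compound 3 is expected at 6000 nM, within 2000 nM to 18000 nM.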

Compound 3, half-maximal inhibitory concentration: > 16000 nM
Compound 3: a limit, no number (the forecaster's own chance of this, stated with the estimate: 10%); middle value at least 2.6-fold (0.42 log units) from the limit.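

In this assay, compound 3 stands as a limit, not a number: the limit of > 16000 nM in this assay, at which 1 of the 3 values shown sits. Pyrrolidin-1-yl gives an at least 3.9-fold higher number from compound 2 to compound 3 (0.59 log units; beyond the scatter), and an at least 8.0-fold higher number from compound 1 to compound 3 (0.90 log units; beyond the scatter). On this double-bonded ring carbon, the series therefore responds to more than the exchange of one phenyl group for another, which gave only a 2.1-fold higher number from compound 1 to compound 2 (0.32 log units; beyond the scatter).

The aromatic ring and the amine hydrogen leave together in this change, so the compounds shown cannot separate them. A cyclohexylamino group, or an N-methyl-N-phenylamino group, would each change only one of the two.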